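Triazole Aryl Swap in a Series Stuck at the Limit

This account rests on a few compounds, and the source may have more. Where it says the series, first, only, none or still open, it means among the compounds named here.

Compound 1, `C=C1C[C@]23C[C@@]1(O)CC[C@H]2c1cc(Br)c(O)c(C)c1[C@@H]3Cn1cc(-c2ccc(C)cc2)nn1`, gives a limit of > 20000 nM.
Compound 2, `C=C1C[C@]23C[C@@]1(O)CC[C@H]2c1ccc(O)c(C)c1[C@@H]3Cn1cc(-c2ccc(OC)cc2)nn1`, gives a limit of > 20000 nM.
Compound 3, `C=C1C[C@]23C[C@@]1(O)CC[C@H]2c1ccc(O)c(C)c1[C@@H]3Cn1cc(-c2ccccn2)nn1`, gives a limit of > 20000 nM.

Every measured value here is a limit of a functional assay on SMMC-7721 cells (Homo sapiens) for cytotoxicity, read by MTT assay, with a stated time of 4 days (on this read-out lower numbers stand for stronger inhibition and higher numbers for weaker inhibition), and not a number: the limit of > 20000 nM in this assay, at which 3 of the 3 values shown sit. Compound 3 therefore stands only at a limit in this assay, with no measured number to place it above or below the others. Among the measured compounds shown here, the single step between measured compounds, a step that the two limits leave unreadable from compound 2 to compound 3, runs from one limit to another, so its size cannot be read.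

Compound 4, `C=C1C[C@]23C[C@@]1(O)CC[C@H]2c1ccc(O)c(C)c1[C@@H]3Cn1cc(-c2ccc(C)cc2)nn1`, differs from compound 3 by the change (4-methylphenyl in place of pyridin-2-yl on an aromatic carbon). For the measured compounds named here, no measured step shows this exact change. The 4-methylphenyl group that enters is already present on compound 1, which sits at the limit. The pyridin-2-yl group that leaves is present on compound 3, which also sits at the limit. Nothing in the measured values points to a move in either direction beyond the scatter. Compound 4 is therefore expected to remain at the limit as well, estimated at 30000 nM, within 15000 nM to 100000 nM. The expected step is a step that the limit leaves unreadable from compound 3 to compound 4, which most likely means a further limit rather than a readable number.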

Compound 4, half-maximal inhibitory concentration: > 20000 nM
Compound 4 was reported as a limit; the forecaster's own chance of this, stated with the estimate: 85%; the middle value is on the limit's open side.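

Compound 4 gives > 20000 nM in this assay, which is a limit and not a number. Its steps from compound 1, compound 2 and compound 3 therefore cannot be read. The compounds shown leave open how they rank against one another and whether any of these group changes alters the result, because all of them share one ceiling: the limit of > 20000 nM in this assay, at which 4 of the 4 values shown sit.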